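The source may hold more compounds than are shown below. What is called first, only, known or untested is meant among the compounds shown, and "the series" means these compounds.

Measured compounds in a functional assay (muscle tissue) with Cavia porcellus as the target; on this read-out lower numbers stand for an effect already at smaller amounts and higher numbers for an effect only at larger amounts of compound:
compound 1 `COC(=O)C1=C(C)N=C(C)/C(=C(\O)OC)C1c1cc(Cl)cc(Cl)c1`: 93.3 nM
compound 2 `COC(=O)C1=C(C)N=C(C)/C(=C(\O)OC)C1c1ccccc1N`: 39800 nM
compound 3 `CCOc1ccccc1C1C(C(=O)OC)=C(C)N=C(C)/C1=C(\O)OC`: 110 nM

Compound 3 stands second highest of the three numbers; compound 1 lies within the scatter of it, compound 2 far beyond. The two recorded steps are both large: a 430-fold higher number from compound 1 to compound 2 (2.63 log units; beyond the scatter) and a 360-fold lower number from compound 2 to compound 3 (2.56 log units; beyond the scatter). Both involve the amino group, which neither compound 3 nor compound 4 carries.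

Compound 4, `COC(=O)C1=C(C)N=C(C)/C(=C(\O)OC)C1c1ccccc1C`, differs from compound 3 by methyl in place of ethoxy on an aromatic carbon. Going by the values given here, no recorded step sets methyl against ethoxy; the only steps bear on amino. Compound 1 gives 93.3 nM and compound 3 gives 110 nM, within the scatter of each other, so a third substituted phenyl lacking amino is expected to fall near them. The expected step of a 1.4-fold higher number from compound 3 to compound 4 (0.13 log units; within the scatter) is therefore none beyond the scatter, though the lack of any direct comparison leaves the range wide. Compound 4 is estimated at 150 nM, with a range of 40 nM to 600 nM in this assay.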

Compound 4, half-maximal effective concentration: 6.03 nM
Estimate against measurement, compound 4: 25-fold (1.40 log units) above; measured number outside the range, below it.
By their numbers in this assay, from the lowest: compound 4; then compounds 1 and 3 (each within the scatter of the next); then compound 2.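

In this assay, the aromatic carbon ortho to a large group responds strongly even without amino: methyl in place of ethoxy gives an 18-fold lower number from compound 3 to compound 4 (1.26 log units; beyond the scatter) and so separates two substituents that both lack amino. Methyl in place of amino gives a 6600-fold lower number from compound 2 to compound 4 (3.82 log units; beyond the scatter), a wider step than either step that involves amino among the earlier compounds. Against the 3,5-dichlorophenyl group, 2-methylphenyl gives a 15-fold lower number from compound 1 to compound 4 (1.19 log units; beyond the scatter), so compound 1 and compound 3, within the scatter of each other, do not mark the lowest level for the series.

On these data alone, whether the low number is particular to methyl or extends to a longer chain such as ethyl, or to a group such as nitrile, at this aromatic carbon remains open. No measurement at hand accounts for the difference between methyl and ethoxy.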